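A few compounds are considered here, and "the series" means these few. Any claim that something is new, unique, unknown or untested is made for them only; others in the source may bear on it.

Of the compounds shown here, three that share a core have so far been measured in an ADME assay on KB cells (Homo sapiens) for cytotoxicity; on this read-out higher numbers stand for an effect only at larger amounts of compound and lower numbers for an effect already at smaller amounts. Compound 1 `COc1cc2c(c(OCc3ccccc3)c1OC)C(=O)[C@]1(OC)C=C[C@H]2N(C(=O)OCC(C)C)N1C(=O)OCC(C)C` gives 94 ug/mL in this assay. Compound 2 `CCCCOc1c(OC)c(OC)cc2c1C(=O)[C@]1(OC)C=C[C@H]2N(C(=O)OCC)N1C(=O)OCC` gives 76 ug/mL in this assay, and compound 3 `CCCCOc1c(OC)c(OC)cc2c1C(=O)[C@]1(OC)C=C[C@H]2N(C(=O)OCC(C)C)N1C(=O)OCC(C)C` gives 22.1 ug/mL in this assay.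

Compounds 3 and 1 differ in a single place: phenyl in place of propyl on a saturated chain carbon bound to an oxygen on an aromatic ring. This change brought a 4.3-fold higher number from compound 3 to compound 1 (0.63 log units; beyond the scatter). The value of compound 2 lies close to that of compound 1, within the scatter of the method, while it stands apart from compound 3 by more than the scatter. How the core of compound 2 differs from the core of compound 3 is not broken down here.

Compound 4 `CCOC(=O)N1[C@@H]2C=C[C@@](OC)(C(=O)c3c2cc(OC)c(OC)c3OCc2ccccc2)N1C(=O)OCC` has not yet been measured in this assay. It differs from compound 2 in one place: phenyl in place of propyl on a saturated chain carbon bound to an oxygen on an aromatic ring. Among the compounds with values here, this is the same change as the one from compound 3 to compound 1, carried out on the other core. Because that change made a 4.3-fold higher number from compound 3 to compound 1 (0.63 log units; beyond the scatter), the step expected here is a 2.9-fold higher number from compound 2 to compound 4 (0.46 log units; beyond the scatter), with some allowance for the fact that the difference between the two cores is not resolved and the step need not repeat in full. Compound 4 is therefore estimated at 220 ug/mL in this assay, with a likely range from 95 ug/mL to 450 ug/mL.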

Compound 4, concentration for half-maximal effect: 215 ug/mL
The estimate for compound 4 lay 1.0-fold (0.01 log units) above the measured number; the measured number falls inside the stated range.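

In this assay, phenyl in place of propyl on a saturated chain carbon bound to an oxygen on an aromatic ring, which is to say benzyloxy in place of butoxy, gave a 2.8-fold higher number from compound 2 to compound 4 (0.45 log units; beyond the scatter), so on this second core too the cytotoxic effect appeared only at larger amounts of compound. Set side by side, the two steps run in the same direction and their sizes cannot be told apart: the same change on two cores in this assay, a 4.3-fold higher number (0.63 log units; beyond the scatter) from compound 3 to compound 1 and a 2.8-fold higher number (0.45 log units; beyond the scatter) from compound 2 to compound 4, 1.5-fold (0.18 log units) apart, within the scatter of two such steps This shows that the change carried over from one core to the other in these four compounds, but it rests on only two pairs and does not show that the step would repeat on any further core, nor does it explain why the number rises.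

The compounds shown leave open how the number would respond to other groups at this place, such as a longer chain or a chain ending in an amine or a carboxylic acid. Within the data shown here, they also leave open whether the step would keep its size with a substituted phenyl in place of the plain one, since butoxy and benzyloxy are the only two groups compared here on both cores.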